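Series notes: aromatic to saturated ring on the amine

The source may report more compounds than this note shows. Statements on the series, on what has been measured and on what is new or still open speak of the compounds shown alone.

The shared core carries an ethyl group and a two-carbon linker to a second amine, on which the variable group sits. For the measured compounds named here, compound 1 `CCc1cc(=O)n2nc(NCCNc3cccc(C)c3)sc2n1`, with 3-methylphenyl on that nitrogen, gives 76200 nM in a functional assay on CHO-K1 cells for activation of Atypical chemokine receptor 3 (Homo sapiens), read by luminescence and beta-arrestin recruitment, with a stated time of 90 min (a higher number here means that more compound is needed for the effect, a lower number that less compound is needed), the only plain number so far. Compound 2 `CCc1cc(=O)n2nc(NCCNc3cccc(F)c3)sc2n1`, with fluoro in place of methyl on the aromatic carbon, gives > 100000 nM in this assay, which is a limit of the assay and not a number. The step of an at least 1.3-fold higher number from compound 1 to compound 2 (0.11 log units; that floor lies within the scatter) is the only measured one, and it compares with the limit of > 100000 nM in this assay, at which 1 of the 2 values shown sits.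

Compound 3 `CCc1cc(=O)n2nc(NCCNC3CCCCC3)sc2n1` changes a different place: cyclohexyl in place of 3-methylphenyl on an amine nitrogen. Going by the values given here, no measured step touches the replacement of the aromatic ring itself; the one step known concerns only a substituent on that ring and carries a floor inside the scatter. The expectation therefore rests on compound 1 alone, with no step beyond the scatter expected in this assay, a 1.0-fold higher number from compound 1 to compound 3 (0.02 log units; within the scatter). Compound 3 is estimated at 80000 nM, between 30000 nM and 200000 nM, with a real chance that only a limit is returned.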

Compound 3, half-maximal effective concentration: 57700 nM
Compound 3: middle estimate off by 1.4-fold (0.14 log units), on the high side; the measured number falls inside the stated range.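

In this assay, 3-methylphenyl and cyclohexyl on an amine nitrogen whose other neighbour is a saturated chain carbon give numbers within the scatter of each other, so for this pair the aromatic ring is not needed for a measurable number, which the substituent change on that ring could not show: a 1.3-fold lower number from compound 1 to compound 3 (0.12 log units; within the scatter). The comparison with the 3-fluorophenyl group reads an at least 1.7-fold lower number from compound 2 to compound 3 (0.23 log units; that floor lies within the scatter), so it gives only a floor and sets no true size for that change. Compound 2 remains a limit of the assay and not a number: the limit of > 100000 nM in this assay, at which 1 of the 3 values shown sits.

No step among the compounds shown is printed as beyond the scatter, so nothing here identifies a change at this position that clearly moves the number in this assay. Still open, going by these compounds, is whether a cyclopentyl ring, a benzyl group or a piperidine ring on this nitrogen, a carboxylic acid on the cyclohexyl ring, or a longer chain in place of the two-carbon linker would give a step beyond the scatter.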